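Replacing the 4-chlorophenyl group of compound 2

This account rests on a few compounds, and the source may have more. Where it says the series, first, only, none or still open, it means among the compounds named here.

In a functional assay on HUVEC cells (Homo sapiens) for inhibition (a lower number here means a stronger inhibitor, a higher number a weaker inhibitor), compound 1 (`COc1cc(/C=C/C(=O)c2cccc(NC(=O)c3cc(Cl)cc(Cl)c3)c2)ccc1O`) gives 0.75 ug/mL and compound 2 (`COc1cc(/C=C/C(=O)c2cccc(NC(=O)c3ccc(Cl)cc3)c2)ccc1O`) gives 0.76 ug/mL on the same scale. For the measured compounds named here, the one measured step of a 1.0-fold higher number from compound 1 to compound 2 (0.01 log units; within the scatter) lies within the scatter, so compound 2 cannot be told apart from compound 1 on these numbers.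

Compound 3 (`COC(=O)C(=O)Nc1cccc(C(=O)/C=C/c2ccc(O)c(OC)c2)c1`) has methoxycarbonyl in place of 4-chlorophenyl on a carbonyl carbon, a difference that reads methoxycarbonyl in place of 4-chlorophenyl on a carbonyl carbon in full. The measured step of a 1.0-fold higher number from compound 1 to compound 2 (0.01 log units; within the scatter) bears on this only loosely, since it swapped one chlorine-bearing phenyl group for another and kept the ring. Going by the values given here, no measured compound shows what happens when that ring leaves. A modest rise in the number in this assay is therefore expected, with wide uncertainty. The expected change is a 2.0-fold higher number from compound 2 to compound 3 (0.30 log units; within the scatter) as a rough estimate. For compound 3 the estimated value is 1.5 ug/mL with an expected range from 0.5 ug/mL to 6 ug/mL in this assay.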

Compound 3, half-maximal inhibitory concentration: 1.5 ug/mL
For compound 3 middle estimate and measured number coincide at the digits printed; the range from low to high includes it.
By their numbers in this assay, from the lowest: compounds 1, 2 and 3 (each within the scatter of the next).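

In this assay, methoxycarbonyl in place of 4-chlorophenyl on a carbonyl carbon gives a 2.0-fold higher number from compound 2 to compound 3 (0.30 log units; within the scatter), and the same group in place of 3,5-dichlorophenyl gives a 2.0-fold higher number from compound 1 to compound 3 (0.30 log units; within the scatter). The earlier pair had kept a chlorine-bearing phenyl ring at this position, whereas these steps show that a group with no ring, no chlorine and two hydrogen-bond acceptors still gives a number within the scatter of both chlorophenyl compounds. Nothing available explains this result.

The compounds shown leave open whether a carboxylic acid, an amine or a longer alkyl chain on this carbonyl carbon would also stay within the scatter. They also leave open how an unsubstituted phenyl group would compare with the two chlorophenyl groups.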